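The compounds below may be only part of what the source reports. "The series", "measured", "known", "first", "only" and "open" are said of these compounds alone.

This series was examined in a functional assay on HeLa cells (Homo sapiens) for inhibition, with a stated time of 72 h; on this read-out lower numbers stand for an effect already at smaller amounts and higher numbers for an effect only at larger amounts of compound. Compound 1, `COc1cc(CNCc2ccncc2)ccc1OCc1ccc(F)cc1`, gives 6400 nM in this assay. Compound 2, `COc1cc(CNCCNc2ccnc3cc(Cl)ccc23)ccc1OCc1ccc(Cl)nc1`, gives 2700 nM, and compound 3, `COc1cc(CNc2nc[nH]n2)ccc1OCc1ccc(Cl)nc1`, gives 69000 nM. Among these three numbers compound 1 stands second highest: compound 2 lies nearest, with a lower number by a margin beyond the scatter, and compound 3 lies furthest, with a higher number by a margin well beyond the scatter. Among the compounds with values here, no two measured compounds differ in only one place, so no single step has yet been read from the numbers.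

Compound 4, `COc1cc(CNCc2ccncc2)ccc1OCc1ccccc1F`, has not been measured. It differs from compound 1 in one place: 2-fluorophenyl in place of 4-fluorophenyl on a saturated chain carbon bound to an oxygen on an aromatic ring. The measured compounds show nothing about what this exchange does, so the step is expected to be none beyond the scatter, a 1.3-fold higher number from compound 1 to compound 4 (0.10 log units; within the scatter). Compound 4 is estimated at 8000 nM in this assay, with a range from 3000 nM to 25000 nM.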

Compound 4, half-maximal effective concentration: 5100 nM
Beside the measured number, compound 4's estimate is 1.6-fold (0.20 log units) above it; the range from low to high includes it.
By their numbers in this assay, from the lowest: compounds 2, 4 and 1 (each within the scatter of the next, the first and the last beyond it); then compound 3.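

In this assay, within the data shown here, exchanging 4-fluorophenyl for 2-fluorophenyl on a saturated chain carbon bound to an oxygen on an aromatic ring gives a 1.3-fold lower number from compound 1 to compound 4 (0.10 log units; within the scatter) as the first step that can be read from a single change. The same atoms, joined differently at this one place, therefore leave the number within the usual scatter, so this read-out does not separate these two fluorophenyl groups. Nothing measured here explains this result.

The compounds shown leave open whether the fluorine matters at all at this place, a question that a phenyl ring with no fluorine, or one carrying a nitrile or a carboxylic acid instead, would address. From the compounds shown here alone, the role of the other parts of the core of compound 1 also stays open, as compound 2 and compound 3 differ from it in more than one place.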